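Swapping Chloro for Methoxy on the Core of Compound 2

The source may hold more compounds than are shown below. What is called first, only, known or untested is meant among the compounds shown, and "the series" means these compounds.

Compound 1, `Cc1ccc(-c2cc(Cl)cc(C(=O)Nc3nn[nH]n3)n2)cc1`, gives 86% in a functional assay on the whole organism with Rattus norvegicus as the target, at a dose of 1 mg/kg by the oral route; on this read-out higher numbers stand for a stronger effect at the one dose given and lower numbers for a weaker effect. Compound 2, `CCc1ccc(-c2cc(Cl)cc(C(=O)Nc3nn[nH]n3)n2)cc1`, gives 49%. Compound 3, `CCCc1ccc(-c2cc(Cl)cc(C(=O)Nc3nn[nH]n3)n2)cc1`, gives 78%.

Compound 2 stands lowest of the three: the step of a number 29 percentage points higher from compound 2 to compound 3 (beyond the scatter) separates it from compound 3, and the step of a number 37 percentage points lower from compound 1 to compound 2 (beyond the scatter) from compound 1. Compound 4, `CCc1ccc(-c2cc(OC)cc(C(=O)Nc3nn[nH]n3)n2)cc1`, differs from compound 2 in one place: methoxy in place of chloro on an aromatic carbon. Every measured step, including a number 8 percentage points lower from compound 1 to compound 3 (within the scatter), concerns the chain on the other ring, so none of them bears on an exchange on the core. With no guide from the measured compounds, compound 4 is expected to stay near compound 2, with a step of a number 1 percentage points higher from compound 2 to compound 4 (within the scatter), and a wide range. The estimate for compound 4 is 50%, between 20% and 80%.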

Compound 4, a percentage reported as inhibition, in the whole organism at one dose (the size of the read-out at that dose, not a potency): 43%
Compound 4: middle estimate off by 7 percentage points, on the high side, and the stated range covers the measured number.
By their numbers in this assay, from the lowest: compounds 4 and 2 (each within the scatter of the next); then compounds 3 and 1 (each within the scatter of the next).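

In this assay, among the compounds shown here, methoxy in place of chloro opposite the ring nitrogen gives a number 6 percentage points lower from compound 2 to compound 4 (within the scatter), the first reading of a change on the core rather than on the chain of the other ring. At this one dose, the position accepts two heavy atoms and a hydrogen-bond acceptor in place of a single chlorine with no difference beyond the scatter. Nothing available explains this outcome.

From the compounds shown here alone, whether an amine or a carboxylic acid at this position would read the same remains open. So does whether the chains of compound 1 and compound 3 would keep their numbers with methoxy on the core.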